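Methylated sulfonamide variant of compound 3: expected potency

The compounds below may be only part of what the source reports. "The series", "measured", "known", "first", "only" and "open" are said of these compounds alone.

Compound 3 `CCCCc1ccc(CNS(=O)(=O)c2ccccc2)c(=O)n1Cc1ccc(-c2ccccc2-c2nn[nH]n2)cc1` gives 7 nM in a functional assay (aorta) for antagonist activity, with Oryctolagus cuniculus as the target; on this read-out lower numbers stand for stronger inhibition and higher numbers for weaker inhibition. Among the three measured compounds it stands second highest; compound 1 `CCCCc1ccc(CNC(=O)OC(C)(C)C)c(=O)n1Cc1ccc(-c2ccccc2-c2nn[nH]n2)cc1` gives 10 nM, and compound 2 `CCCCc1ccc(CNC(=O)N(C)C)c(=O)n1Cc1ccc(-c2ccccc2-c2nn[nH]n2)cc1` gives 2 nM. The step from compound 1 to compound 3 was a 1.4-fold lower number from compound 1 to compound 3 (0.15 log units; within the scatter), whereas compound 2 sits apart, with a 3.5-fold higher number from compound 2 to compound 3 (0.54 log units; beyond the scatter) and a 5.0-fold lower number from compound 1 to compound 2 (0.70 log units; beyond the scatter).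

Compound 4 `CCCCc1ccc(CN(C)S(=O)(=O)c2ccc(C)cc2)c(=O)n1Cc1ccc(-c2ccccc2-c2nn[nH]n2)cc1` differs from compound 3 by methyl((4-methylphenyl)sulfonyl)amino in place of (phenylsulfonyl)amino on a saturated chain carbon bound to an aromatic carbon. Going by the values given here, no measured step touches either the methyl on the sulfonamide nitrogen or the methyl on the aromatic ring; the measured steps only show that exchanges at this amine nitrogen, between carbamate, urea and sulfonamide, moved this assay by modest amounts at most. On that basis the expected step of a 1.4-fold higher number from compound 3 to compound 4 (0.15 log units; within the scatter) from compound 3 to compound 4 is small, with no firm direction. Compound 4 is therefore estimated at 10 nM, within a range of 2.5 nM to 40 nM.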

Compound 4, half-maximal inhibitory concentration: 8 nM
Beside the measured number, compound 4's estimate is 1.3-fold (0.10 log units) above it; the range from low to high includes it.
By their numbers in this assay, from the lowest: compound 2; then compounds 3, 4 and 1 (each within the scatter of the next).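

Replacing (phenylsulfonyl)amino with methyl((4-methylphenyl)sulfonyl)amino, which takes the group from 1 hydrogen-bond donor to 0, gave a 1.1-fold higher number from compound 3 to compound 4 (0.06 log units; within the scatter) in this assay and so shows that this position tolerates the loss of that donor together with the added methyl groups. The urea keeps its separate standing, with a 4.0-fold higher number from compound 2 to compound 4 (0.60 log units; beyond the scatter) while the carbamate shows a 1.3-fold lower number from compound 1 to compound 4 (0.10 log units; within the scatter) and so remains level with the methylated sulfonamide. Nothing available bears on why the read-out held at this position.

The methyl on the sulfonamide nitrogen and the methyl on the aromatic ring entered together, so the share of each remains unresolved, and they could even be offsetting each other. Also open, from the compounds shown here alone, is whether an ethyl on that nitrogen, or a methoxy or carboxylic acid on the aromatic ring, would leave the read-out unchanged.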